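Quinolin-2-yl replaces 2-methoxyphenyl on the shared core

A few compounds are considered here, and "the series" means these few. Any claim that something is new, unique, unknown or untested is made for them only; others in the source may bear on it.

Three compounds share one core and differ only in the aryl group on a double-bonded chain carbon bound to a double-bonded ring carbon. In a functional assay on A549 cells (Homo sapiens) for antiproliferative activity, read by MTT assay (a higher number here means a weaker inhibitor, a lower number a stronger inhibitor), compound 1 `O=C1N=C(N2CCC[C@H]2C(=O)Nc2ccc3ncnc(Nc4cccc(Cl)c4)c3c2)S/C1=C/c1ccc(-c2ccccc2)cc1` gives 24200 nM. Compound 2 `O=C1N=C(N2CCC[C@H]2C(=O)Nc2ccc3ncnc(Nc4cccc(Cl)c4)c3c2)S/C1=C/c1cccs1` gives 6100 nM in this assay, and the step of a 4.0-fold lower number from compound 1 to compound 2 (0.60 log units; beyond the scatter) is a modest change. Compound 3 `COc1ccccc1/C=C1/SC(N2CCC[C@H]2C(=O)Nc2ccc3ncnc(Nc4cccc(Cl)c4)c3c2)=NC1=O` reaches only a limit in this assay, > 50000 nM, so it sits at the limit of > 50000 nM in this assay, at which 1 of the 3 values shown sits, and the steps of an at least 2.0-fold higher number from compound 1 to compound 3 (0.31 log units; beyond the scatter) and an at least 8.1-fold higher number from compound 2 to compound 3 (0.91 log units; beyond the scatter) can only be given as lower bounds. Compound 4 `O=C1N=C(N2CCC[C@H]2C(=O)Nc2ccc3ncnc(Nc4cccc(Cl)c4)c3c2)S/C1=C/c1ccc2ccccc2n1` carries the change (quinolin-2-yl in place of 2-methoxyphenyl on a double-bonded chain carbon bound to a double-bonded ring carbon). Since compound 3 is a limit, the step of an at least 2.5-fold lower number from compound 3 to compound 4 (0.39 log units; beyond the scatter) is estimated as a bound at most. Given that aryl changes here moved the number across the range shown, compound 4 is expected to give 20000 nM, between 5000 nM and 60000 nM.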

Compound 4, half-maximal inhibitory concentration: > 50000 nM
Compound 4 gave a limit, no number; the forecaster's own chance of this, stated with the estimate: 30%; at least 2.5-fold (0.39 log units) between middle value and limit.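

Quinolin-2-yl, like 2-methoxyphenyl, leaves the compound at a limit, and the step between compound 3 and compound 4 cannot be read: the limit of > 50000 nM in this assay, at which 2 of the 4 values shown sit.

In this assay the new result gives an at least 8.1-fold higher number from compound 2 to compound 4 (0.91 log units; beyond the scatter) and an at least 2.0-fold higher number from compound 1 to compound 4 (0.31 log units; beyond the scatter), so a second aryl group falls behind both compounds with readable values, and compound 2 remains the strongest of the four.

As far as these compounds go, the true values of compound 3 and compound 4 stay open, since each is known only as a limit. Also open, from the compounds shown here alone, is whether furan-2-yl or a 4-aminophenyl group at this place would match compound 2.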